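This account rests on a few compounds, and the source may have more. Where it says the series, first, only, none or still open, it means among the compounds named here.

Compound 1 `O=C(NC[C@@H]1CCCC[C@H]1O)NC1CCN(Cc2ccn(-c3ccc(C(F)(F)F)cc3)c2)CC1`: 46 nM
Compound 2 `COc1ccc(OC2CN(C(=O)NC3CCN(Cc4ccn(-c5ccc(C(F)(F)F)cc5)c4)CC3)C2)cc1`: 49 nM
Compound 3 `O=C(NC1CCN(Cc2ccn(-c3ccc(C(F)(F)F)cc3)c2)CC1)N1CCn2cccc2C1c1ccccc1`: 10 nM

All three numbers come from an assay on HEK293 cells for displacement of a labelled ligand from melanin-concentrating hormone receptor 1 (Homo sapiens); a higher number here means a weaker inhibitor, a lower number a stronger inhibitor. Compound 1 stands second highest of the three: compound 2 sits within the scatter of it, while compound 3 lies clearly lower, beyond the scatter. Going by the values given here, no two measured compounds differ in only one place, so no single step can be read off among them.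

Compound 4 `O=C(NC1CCN(Cc2ccn(-c3ccc(C(F)(F)F)cc3)c2)CC1)NS(=O)(=O)c1ccc(F)cc1` has not yet been measured in this assay. It differs from compound 1 in one place: (4-fluorophenyl)sulfonyl in place of (2-hydroxycyclohexyl)methyl on an amide-type nitrogen. A six-membered non-aromatic ring of carbon only carrying one hydrogen-bond donor gives way to a six-membered aromatic ring of carbon only with no hydrogen-bond donors. Among the compounds with values here, no measured pair shows a change of this kind, so the expectation rests on the spread alone. A rise in the number beyond the scatter is expected, estimated as a 3.3-fold higher number from compound 1 to compound 4 (0.51 log units; beyond the scatter). For compound 4 the estimate is 150 nM, within a range from 40 nM to 600 nM.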

Compound 4, half-maximal inhibitory concentration: 617 nM
Compound 4: the middle estimate sits 4.1-fold (0.61 log units) below what was measured; the whole stated range lies below it.
By their numbers in this assay, from the lowest: compound 3; then compounds 1 and 2 (each within the scatter of the next); then compound 4.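

At this amide-type nitrogen the group matters a great deal: putting (4-fluorophenyl)sulfonyl in place of (2-hydroxycyclohexyl)methyl gives a 13-fold higher number from compound 1 to compound 4 (1.13 log units; beyond the scatter) in this assay, so this position does not accept every group equally. Nothing shown gives a reason for the size of this step.

This single step swaps the ring, the hydroxyl and the sulfonyl together, so their shares cannot be separated. From the compounds shown here alone, how a cyclohexylmethyl group without the hydroxyl, or a (4-fluorophenyl)methyl group without the sulfonyl, would score stays open.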